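Swapping a ring fluorine for a nitro group

This account rests on a few compounds, and the source may have more. Where it says the series, first, only, none or still open, it means among the compounds named here.

Compound 1: `O=C(CSc1nnc(-c2ccncc2)o1)N/N=C/c1ccc(F)cc1` gives 15700 nM in a functional assay on SW 1116 cells (Homo sapiens) for cytotoxicity, read by MTT assay, with a stated time of 48 h; on this read-out higher numbers stand for weaker inhibition and lower numbers for stronger inhibition.
Compound 2: `O=C(CSc1nnc(-c2ccncc2)o1)N/N=C/c1cccc(F)c1` gives 26700 nM in this assay.

Compound 2 stands at one end of these two numbers, yet a 1.7-fold higher number from compound 1 to compound 2 (0.23 log units; within the scatter) means compound 1 cannot be separated from it. Compound 3, `O=C(CSc1nnc(-c2ccncc2)o1)N/N=C/c1ccccc1[N+](=O)[O-]`, differs from compound 2 by 2-nitrophenyl in place of 3-fluorophenyl on a carbon with a double bond to nitrogen. Among the compounds with values here, the single measured step only moved a fluorine between ring positions and stayed within the scatter; no measured step exchanges fluorine for a nitro group, so it bears on the change only loosely. No step beyond the scatter is therefore expected in this assay. Compound 3 is estimated at 25000 nM, with a range of 8000 nM to 80000 nM. This expected step is a 1.1-fold lower number from compound 2 to compound 3 (0.03 log units; within the scatter).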

Compound 3, half-maximal inhibitory concentration: 30700 nM
The estimate for compound 3 lay 1.2-fold (0.09 log units) below the measured number, and the stated range covers the measured number.
By their numbers in this assay, from the lowest: compounds 1, 2 and 3 (each within the scatter of the next).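

In this assay the 2-nitrophenyl group brings a 1.1-fold higher number from compound 2 to compound 3 (0.06 log units; within the scatter) and a 2.0-fold higher number from compound 1 to compound 3 (0.29 log units; within the scatter) so neither step separates compound 3 from the fluorine compounds. This position therefore now holds a ring with a nitro group as well as a ring with fluorine, with no step beyond the scatter. Nothing measured here accounts for this result. Within the data shown here, whether this position responds at all remains open, as every step so far stays within the scatter. An amine or a carboxylic acid on this ring might still show a real change.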